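The source may report more compounds than this note shows. Statements on the series, on what has been measured and on what is new or still open speak of the compounds shown alone.

Compound 1 `CS(=O)(=O)c1ccc(-c2cnc3[nH]cc(-c4nnc(-c5ccc(F)cc5)o4)c(=O)c3c2)cc1`: 11.1%
Compound 2 `N#Cc1ccc(-c2cnc3[nH]cc(-c4nnc(-c5ccc(Cl)cc5)o4)c(=O)c3c2)cc1`: 12.7%

In a functional assay on HepG2 cells (Homo sapiens) for inhibition, read by MTT assay, with a stated time of 24 h, tested at 10 uM (on this read-out lower numbers stand for less inhibition of growth and higher numbers for more inhibition of growth at the one concentration tested), compound 1 gives 11.1%, the smaller of the two numbers shown. Compound 2 gives 12.7%, and the gap between them lies within the usual scatter of this measurement, so neither compound can be said to inhibit growth more than the other; both sit at a low level of inhibition.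

Compound 3 `Cc1cccc(-c2nnc(-c3c[nH]c4ncc(-c5ccc(S(C)(=O)=O)cc5)cc4c3=O)o2)c1` has not been measured. It differs from compound 1 in a single place: 3-methylphenyl in place of 4-fluorophenyl on an aromatic carbon. Going by the values given here, no two measured compounds differ in only one place, so no measured step shows what such a change does. What the data do show is that two compounds carrying different groups at that same place, and elsewhere, both stay at low inhibition. On that basis the step of a number 0.9 percentage points higher from compound 1 to compound 3 (within the scatter) is expected to be small, with no change beyond the scatter. Compound 3 is therefore estimated at 12% in this assay, within a range of 2% to 25%.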

Compound 3, percent growth inhibition at one concentration: 13.3%
Compound 3: middle estimate off by 1.3 percentage points, on the low side; the measured number falls inside the stated range.
By their numbers in this assay, from the lowest: compounds 1, 2 and 3 (each within the scatter of the next).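

In this assay, putting 3-methylphenyl in place of 4-fluorophenyl on an aromatic carbon of the five-membered aromatic ring with 2 nitrogen and 1 oxygen gives a number 2.2 percentage points higher from compound 1 to compound 3 (within the scatter). Going by these compounds alone, this is the first comparison at this position in which only one place differs, and it does not separate the two compounds. The two groups match in the counts available, with 7 heavy atoms, one six-membered aromatic ring of carbon only and 0 hydrogen-bond donors or acceptors each, so the step tests only a narrow exchange, and no measurement is available that could explain the outcome.

As far as these compounds go, whether a group of a different kind at this position, such as an aminophenyl, a carboxyphenyl or a longer alkyl chain, would move the number beyond the scatter stays open. From the compounds shown here alone, compound 2 differs from compound 1 in two places, so the separate effects of its nitrile and its 4-chlorophenyl group also remain unknown.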